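Three hydroxyphenyl groups on a shared core, rearranged

The source may report more compounds than this note shows. Statements on the series, on what has been measured and on what is new or still open speak of the compounds shown alone.

The series holds three compounds built on the same core with three hydroxyphenyl groups, and they differ only in how those groups are placed. Compound 1, `Oc1cccc(-c2cc(-c3cccc(O)c3)nc(-c3ccccc3O)c2)c1`, is tested in a functional assay on HCT-15 cells (Homo sapiens) for cytotoxicity, read by CCK-8 assay, with a stated time of 4 days (on this read-out lower numbers stand for stronger inhibition and higher numbers for weaker inhibition), and gives only a limit, > 50000 nM. Compound 2, `Oc1cccc(-c2cc(-c3ccccc3O)cc(-c3cccc(O)c3)n2)c1`, gives 5150 nM in this assay, the only measured number shown. The other value recorded in the set is the limit of compound 1, as noted in the limit of > 50000 nM in this assay, at which 1 of the 2 values shown sits. Since compounds 1 and 2 differ in more than one place, their values are simply stated side by side.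

Compound 3, `Oc1cccc(-c2cc(-c3ccccc3O)cc(-c3ccccc3O)n2)c1`, has not yet been measured. It differs from compound 2 by 2-hydroxyphenyl in place of 3-hydroxyphenyl on an aromatic carbon. Going by the values given here, with no measured step of this kind available, the size of the change is uncertain; a modest loss beyond the scatter is expected, with some chance that the result comes back only as a limit. For compound 3 in this assay the expected value is 12000 nM, within 4000 nM to 40000 nM, which means an expected step of a 2.3-fold higher number from compound 2 to compound 3 (0.37 log units; beyond the scatter).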

Compound 3, half-maximal inhibitory concentration: 3390 nM
Compound 3: the middle estimate sits 3.5-fold (0.55 log units) above what was measured, and the stated range ends above it.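

At the aromatic carbon next to the ring nitrogen, 2-hydroxyphenyl in place of 3-hydroxyphenyl gives a 1.5-fold lower number from compound 2 to compound 3 (0.18 log units; within the scatter) in this assay, so compound 2 and compound 3 cannot be told apart and this position accepts either group in this assay. The same exchange on a different aromatic carbon of the shared core gives an at least 14-fold lower number from compound 1 to compound 3 (1.16 log units; beyond the scatter), which shows that one exchange can matter little in one place and a great deal in another. The value of compound 1 is a limit and not a number, so this second step gives only a minimum size: the limit of > 50000 nM in this assay, at which 1 of the 3 values shown sits.

From the compounds shown here alone, what remains open is how a methoxy group or an amine in place of the hydroxyl would read at either position, and so whether the hydroxyl itself matters to the result. The values also give no reason why the two places differ, and with so few compounds shown, the contrast between them rests on a single pair at each place.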